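Compound 2 to compound 3: a changed chain

This account rests on a few compounds, and the source may have more. Where it says the series, first, only, none or still open, it means among the compounds named here.

Compound 1 `O=C(CCCCCCOc1no[n+]([O-])c1S(=O)(=O)c1ccccc1)NO` gives 9930 nM
Compound 2 `O=C(CCCCCCCOc1no[n+]([O-])c1S(=O)(=O)c1ccccc1)NO` gives 9300 nM

In a functional assay on U-937 cells (Homo sapiens) for inhibition, read by MTT assay, with a stated time of 48 h (a lower number here means a stronger inhibitor, a higher number a weaker inhibitor), compound 2 gives 9300 nM, level within the scatter with compound 1 at 9930 nM. Compound 3 `O=C(NO)OCCOCCOc1no[n+]([O-])c1S(=O)(=O)c1ccccc1` differs from compound 2 in its chain: 2-((hydroxycarbamoyl)oxy)ethoxy in place of 5-(hydroxycarbamoyl)pentyl on a saturated chain carbon, two bonds along the chain from an oxygen on an aromatic ring. Going by the values given here, the only measured guide is a 1.1-fold lower number from compound 1 to compound 2 (0.03 log units; within the scatter), and no measured step covers the 2-((hydroxycarbamoyl)oxy)ethoxy group. A step beyond the scatter is therefore not expected, and the estimated step is a 1.3-fold higher number from compound 2 to compound 3 (0.11 log units; within the scatter). Compound 3 is expected at 12000 nM, with an estimated range of 4000 nM to 40000 nM.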

Compound 3, half-maximal inhibitory concentration: 12100 nM
The estimate for compound 3 lay 1.0-fold (0.00 log units) below the measured number, within the range that was stated.
By their numbers in this assay, from the lowest: compounds 2, 1 and 3 (each within the scatter of the next).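

In this assay, 2-((hydroxycarbamoyl)oxy)ethoxy in place of 5-(hydroxycarbamoyl)pentyl gives a 1.3-fold higher number from compound 2 to compound 3 (0.11 log units; within the scatter), and the same group in place of 4-(hydroxycarbamoyl)butyl gives a 1.2-fold higher number from compound 1 to compound 3 (0.09 log units; within the scatter). The earlier compounds shown here differed only in chain length, whereas these steps show that a chain with more oxygen, its hydroxycarbamoyl joined through an oxygen, stays level with both at this position. No evidence is available that bears on this result. On these data alone, whether a carboxylic acid or an amine in place of the hydroxycarbamoyl, or a longer chain, would move the number beyond the scatter stays open.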